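A few compounds are considered here, and "the series" means these few. Any claim that something is new, unique, unknown or untested is made for them only; others in the source may bear on it.

In a functional assay on Cortical neurone cells (Mus musculus, strain C57BL/6), read by FLIPR and calcium flux, with a stated time of 8 min (a higher number here means a weaker inhibitor, a lower number a stronger inhibitor), the measured compounds read:

- compound 1 `O=c1cc(-c2ccccc2)[nH]c2nc(Cc3ccccc3)nn12` gives 1310 nM
- compound 2 `O=c1cc(-c2ccccc2)[nH]c2nc(Cc3ccc(F)cc3)nn12` gives 2520 nM
- compound 3 `O=c1cc(-c2ccccc2)[nH]c2nc(Cc3ccc(Cl)cc3)nn12` gives 1830 nM

Compound 3 stands within the scatter of the other two (a 1.4-fold higher number from compound 1 to compound 3 (0.15 log units; within the scatter) and a 1.4-fold lower number from compound 2 to compound 3 (0.14 log units; within the scatter)), and the fluoro step also stays inside it (a 1.9-fold higher number from compound 1 to compound 2 (0.28 log units; within the scatter)). No order can be drawn among these three values.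

Compound 4 (`Cc1ccc(-c2nc3[nH]c(-c4ccccc4)cc(=O)n3n2)cc1`) differs from compound 3 by a larger change (4-methylphenyl in place of 4-chlorobenzyl on an aromatic carbon), with 4-methylphenyl in place of 4-chlorobenzyl on an aromatic carbon. Among the compounds with values here, no measured step covers this exchange, and no measured compound carries 4-methylphenyl. Within the data shown here, the nearest evidence is the halogen steps, which show only that changes on an aromatic carbon of the benzyl group stayed small (a 1.4-fold higher number from compound 1 to compound 3 (0.15 log units; within the scatter) and a 1.9-fold higher number from compound 1 to compound 2 (0.28 log units; within the scatter)).

A modest move towards a higher number is therefore expected, though the direction is uncertain. The expected change is a 1.6-fold higher number from compound 3 to compound 4 (0.21 log units; within the scatter) and remains only an estimate for now. The estimate for compound 4 is 3000 nM (expected range 800 nM to 11000 nM) in this series.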

Compound 4, half-maximal inhibitory concentration: 3210 nM
Beside the measured number, compound 4's estimate is 1.1-fold (0.03 log units) below it, within the range that was stated.
By their numbers in this assay, from the lowest: compounds 1, 3, 2 and 4 (each within the scatter of the next, the first and the last beyond it).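

Within the data shown here, compound 4 is the first in this set to change the whole group on the aromatic carbon of the five-membered aromatic ring with 3 nitrogen, whereas the earlier compounds varied only a halogen on the benzyl group. In this assay the exchange for 4-methylphenyl gives a 1.8-fold higher number from compound 3 to compound 4 (0.24 log units; within the scatter) and a 1.3-fold higher number from compound 2 to compound 4 (0.11 log units; within the scatter), so these two steps show no change that can be told from the scatter. Only the comparison with the unsubstituted benzyl group leaves the scatter, with a 2.5-fold higher number from compound 1 to compound 4 (0.39 log units; beyond the scatter), and that shift remains modest.

No data shown here offer an explanation for that shift. The compounds leave open how this position would respond to a group without a carbon aromatic ring, such as an amine, a carboxylic acid or a longer chain.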